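A few compounds are considered here, and "the series" means these few. Any claim that something is new, unique, unknown or untested is made for them only; others in the source may bear on it.

Three compounds of a shared core have been examined in an ADME assay on Vero cells (Chlorocebus sabaeus) for cytotoxicity, read by neutral red uptake, with a stated time of 72 h; a lower number here means a stronger inhibitor, a higher number a weaker inhibitor. Compound 1 `Clc1ccc2c(NCCNc3nccc(Nc4ccccc4)n3)ccnc2c1` gives "not active" (no number reported), and compound 2 `COc1cc(Nc2ccnc(NCCNc3ccnc4cc(Cl)ccc34)n2)cc(OC)c1` likewise gives "not active" (no number reported). Among the compounds with values here, compound 3 `Fc1ccc(Nc2ccnc(NCCCNc3ccnc4cc(Cl)ccc34)n2)cc1` is the one member of the set for which a number is reported: in this assay compound 3 gives 13700 nM, so it stands as the only point of reference among the three, with the other two entries carrying no figure at all.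

The next compound, compound 4 `Cc1ccc(Nc2ccnc(NCCCNc3ccnc4cc(Cl)ccc34)n2)cc1`, differs from compound 3 in a single place: methyl in place of fluoro on an aromatic carbon. Within the data shown here, no step between two measured compounds of this set is available, so the expectation for compound 4 rests on the single reported number of compound 3 and on the small size of the change. For a one-atom exchange of this kind, the step from compound 3 to compound 4 in this assay is expected to be a 1.1-fold lower number from compound 3 to compound 4 (0.06 log units; within the scatter), that is, nothing beyond the usual scatter in either direction. Compound 4 is therefore estimated at 12000 nM, within a range of 5000 nM to 30000 nM.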

Compound 4, half-maximal inhibitory concentration: 18500 nM
Estimate against measurement, compound 4: 1.5-fold (0.19 log units) below; the range from low to high includes it.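

Within the data shown here, this pair gives the first comparison in this assay between two compounds that differ in one place, and the step is a 1.4-fold higher number from compound 3 to compound 4 (0.13 log units; within the scatter). At this position on the aromatic ring, para to a large group, 4-fluorophenyl and 4-methylphenyl therefore cannot be told apart, and this exchange of one heavy atom for another has no effect that can be read beyond the usual scatter. Nothing in the available data offers an explanation for this result.

This single pair cannot show whether a larger or more different group at the same position, such as an amine, a nitrile or a carboxylic acid, would also leave the number within the scatter. It also leaves open whether the same exchange would behave in this way on a compound with a different linking chain.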